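A few compounds are considered here, and "the series" means these few. Any claim that something is new, unique, unknown or untested is made for them only; others in the source may bear on it.

Measured in a functional assay on A549 cells (Homo sapiens) for antiproliferative activity, read by MTT assay, with a stated time of 72 h; on this read-out lower numbers stand for stronger inhibition and higher numbers for weaker inhibition:
- Compound 1 `O=C(N/N=C/c1ccccc1)Nc1ccc(Oc2ccnc3[nH]ccc23)c(F)c1`: 2500 nM
- Compound 2 `O=C(N/N=C/c1ccc(O)cc1O)Nc1ccc(Oc2ccnc3[nH]ccc23)c(F)c1`: 5840 nM
- Compound 3 `O=C(N/N=C/c1ccccc1)Nc1ccc(Oc2ccnc3[nH]ccc23)cc1`: 17200 nM

Compound 3 has the highest number of the three. Compound 4 `COc1ccc(/C=N/NC(=O)Nc2ccc(Oc3ccnc4[nH]ccc34)cc2)cc1` differs from it at one place: methoxy in place of hydrogen on an aromatic carbon, or phenyl to 4-methoxyphenyl. The closest measured change is on that same phenyl: a 2.3-fold higher number from compound 1 to compound 2 (0.37 log units; beyond the scatter), a modest step. The other step, a 6.9-fold higher number from compound 1 to compound 3 (0.84 log units; beyond the scatter), is at a different place and bears only indirectly. From the compounds shown here alone, neither step involves methoxy, so the direction remains open. The expected step in this assay is a 1.1-fold lower number from compound 3 to compound 4 (0.06 log units; within the scatter), which would stay within the scatter. Compound 4 is estimated at 15000 nM, with an expected range of 5000 nM to 40000 nM.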

Compound 4, half-maximal inhibitory concentration: 4300 nM
For compound 4 the middle estimate is 3.5-fold (0.54 log units) above the measured one; measured number below the stated range.
By their numbers in this assay, from the lowest: compounds 1, 4 and 2 (each within the scatter of the next, the first and the last beyond it); then compound 3.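

Methoxy in place of hydrogen on the aromatic carbon para to a large group lowers the number in this assay (a 4.0-fold lower number from compound 3 to compound 4 (0.60 log units; beyond the scatter)). The only earlier change on this ring went the other way (a 2.3-fold higher number from compound 1 to compound 2 (0.37 log units; beyond the scatter)), so substitution here is not uniformly unfavourable across the compounds shown. No available evidence accounts for the step.

From the compounds shown here alone, whether methoxy gives a similar step when fluoro is present, as in compound 1, remains open. Also open, going by these compounds, is whether an amine or a chlorine atom at this place would behave like methoxy.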